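Aryl Substituent Changes on a Piperazine-Linked Nicotinamide Series

This account rests on a few compounds, and the source may have more. Where it says the series, first, only, none or still open, it means among the compounds named here.

Measured compounds:
- compound 1, `CN(C)C(=O)c1cccnc1NCCCN1CCN(c2ccccc2OC(F)(F)F)CC1`: 100 nM
- compound 2, `CN(C)C(=O)c1cccnc1NCCCN1CCN(c2ccccc2OCC(F)(F)F)CC1`: 15.9 nM
- compound 3, `Cc1ccccc1N1CCN(CCCNc2ncccc2C(=O)N(C)C)CC1`: 10 nM

In a functional assay on aorta for antagonist activity at Alpha-1D adrenergic receptor (Rattus norvegicus) (a lower number here means tighter binding, a higher number weaker binding), compound 3 gives the lowest of the three numbers. Its nearest neighbour is compound 2, with a 1.6-fold lower number from compound 2 to compound 3 (0.20 log units; within the scatter); the furthest is compound 1, with a 10-fold lower number from compound 1 to compound 3 (1.00 log units; beyond the scatter). Compound 4, `COc1cc(C)ccc1N1CCN(CCCNc2ncccc2C(=O)N(C)C)CC1`, carries 2-methoxy-4-methylphenyl in place of 2-methylphenyl on an amine nitrogen in a ring. Going by the values given here, no measured step touches a methoxy or a second methyl on this ring; the steps that bear on it only show that the group on this phenyl can move the number, as in a 10-fold lower number from compound 1 to compound 3 (1.00 log units; beyond the scatter) and a 6.3-fold lower number from compound 1 to compound 2 (0.80 log units; beyond the scatter), whereas a 1.6-fold lower number from compound 2 to compound 3 (0.20 log units; within the scatter) stays within the scatter. Among the compounds with values here, since the one compound with an oxygen on this ring in a small group, compound 1, gave 100 nM, a somewhat higher number than compound 3 is expected for compound 4, though only a modest one: the estimate is a 1.8-fold higher number from compound 3 to compound 4 (0.26 log units; within the scatter). Compound 4 is therefore estimated at 18 nM in this assay, with a range from 5 nM to 70 nM.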

Compound 4, dissociation constant: 39.8 nM
For compound 4 the middle estimate is 2.2-fold (0.34 log units) below the measured one; the measured number falls inside the stated range.
By their numbers in this assay, from the lowest: compounds 3 and 2 (each within the scatter of the next); then compound 4; then compound 1.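

In this assay, a 4.0-fold higher number from compound 3 to compound 4 (0.60 log units; beyond the scatter) shows that 2-methoxy-4-methylphenyl in place of 2-methylphenyl on the amine nitrogen in the ring moves the number beyond the scatter. Going by these compounds alone, the earlier steps exchanged only one group on this phenyl for another, and every oxygen-linked group among them carried fluorine, whereas compound 4 has a methoxy without fluorine and still stays on the higher side of compound 3. No measurement is available that would explain this step.

The compounds shown leave open how much of the step belongs to the methoxy and how much to the second methyl, which enter together. They also leave open what an ethoxy group, a chlorine or an amine on this phenyl would do to the number.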